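This account rests on a few compounds, and the source may have more. Where it says the series, first, only, none or still open, it means among the compounds named here.

Measured so far in a functional assay on SW620/5-FU cells (Homo sapiens) for cytotoxicity, read by MTT assay, with a stated time of 48 h, in the presence of a further agent that is not named here; on this read-out lower numbers stand for an effect already at smaller amounts and higher numbers for an effect only at larger amounts of compound:
compound 1 `Cc1nn(C)c2nc(NNC(=O)Nc3cc(Cl)nc(Cl)c3)cc(-c3ccc(Cl)s3)c12`: 29400 nM
compound 2 `CCCc1cc(NNC(=O)Nc2cc(Cl)nc(Cl)c2)nc2c1cnn2C`: 38700 nM

Compound 1 has the lowest of the two numbers, but compound 2 lies within the scatter of it, so the two cannot be told apart. Compound 3 `Cc1nn(C)c2nc(NNC(=O)Nc3cc(Cl)nc(Cl)c3)cc(-c3ccco3)c12` has not been run in this assay. It differs from compound 1 in one place: furan-2-yl in place of 5-chlorothiophen-2-yl on an aromatic carbon. Among the measured compounds shown here, no step between measured compounds covers such a change, so there is nothing in the data to size it. The step from compound 1 to compound 3 is expected to be small, if anything a slightly higher number, as a 1.4-fold higher number from compound 1 to compound 3 (0.13 log units; within the scatter). Compound 3 is expected to give about 40000 nM in this assay, in the range 15000 nM to 100000 nM.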

Compound 3, half-maximal effective concentration: > 100000 nM
Compound 3: only a limit was reported (the forecaster's own chance of this, stated with the estimate: 20%); at least 2.5-fold (0.39 log units) between middle value and limit.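

In this assay, among the compounds shown here, this aromatic carbon, opposite the ring nitrogen, is the first place where a single change can be sized: furan-2-yl in place of 5-chlorothiophen-2-yl gives an at least 3.4-fold higher number from compound 1 to compound 3 (0.53 log units; beyond the scatter). The exchange of one five-membered aromatic ring for another at this carbon is therefore not neutral, even though the hydrogen-bond counts of the two groups are the same. The reading for compound 3 is a limit and not a number: the limit of > 100000 nM in this assay, at which 1 of the 3 values shown sits.

Going by these compounds, the true size of the step remains open. Sulfur and chlorine leave together here, so whether either alone accounts for the step remains open too; a plain thiophen-2-yl or a 5-chlorofuran-2-yl group at this carbon would separate the two.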